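The compounds below may be only part of what the source reports. "The series", "measured", "known", "first", "only" and "open" are said of these compounds alone.

Compound 1 `COc1cc(-c2cc(/C=C/C(=O)c3ccc(Cl)c(Cl)c3)[nH]n2)cc(OC)c1OC`: 16%
Compound 2 `COc1ccc(C(=O)/C=C/c2cc(-c3cc(OC)c(OC)c(OC)c3)n[nH]2)cc1`: -92%

In a functional assay on LOX IMVI cells (Homo sapiens) for cytotoxicity, read by sulforhodamine B assay, with a stated time of 48 h, tested at 10 uM (on this read-out lower numbers stand for a stronger effect and higher numbers for a weaker effect at the one concentration tested), compound 1 gives 16%, the higher of the two numbers measured; compound 2 gives -92%. Among the compounds with values here, the only measured step, a number 108 percentage points lower from compound 1 to compound 2 (beyond the scatter), swaps the aryl group on the carbonyl carbon, the same place that changes on the way to compound 3 `COc1cc(-c2cc(/C=C/C(=O)c3ccc(F)c(F)c3)[nH]n2)cc(OC)c1OC`: 3,4-difluorophenyl in place of 3,4-dichlorophenyl on a carbonyl carbon. That step is large, but it involves different groups, so it gives only a loose guide. Compound 3 is therefore expected to show a modest step, a number 11 percentage points lower from compound 1 to compound 3 (beyond the scatter), and is estimated at 5%, within -55% to 55%.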

Compound 3, a percentage reported as activity, at one concentration (the size of the read-out at that concentration, not a potency): 8%
Compound 3: the middle estimate sits 3 percentage points below what was measured; low and high end bracket the measured number.
By their numbers in this assay, from the lowest: compound 2; then compounds 3 and 1 (each within the scatter of the next).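

In this assay, within the data shown here, the exchange of 3,4-dichlorophenyl for 3,4-difluorophenyl on the carbonyl carbon gives no step that can be told from scatter (a number 8 percentage points lower from compound 1 to compound 3 (within the scatter)), so these two dihalogenated groups cannot be separated here. The 4-methoxyphenyl group now stands apart from both of them (a number 100 percentage points higher from compound 2 to compound 3 (beyond the scatter)). Nothing measured here accounts for either step. On these data alone, what a phenyl carrying a dimethylamino group or a carboxylic acid would give on this carbonyl carbon stays open, as does the effect of a single halogen.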